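Trading an Aromatic Amine Substituent for a Cyclopentyl Ring

The compounds below may be only part of what the source reports. "The series", "measured", "known", "first", "only" and "open" are said of these compounds alone.

Of the compounds shown here, three built on one shared core have been tested in a functional assay on MCF7 cells (Homo sapiens) for inhibition, read by sulforhodamine B assay; on this read-out higher numbers stand for weaker inhibition and lower numbers for stronger inhibition. Compound 1 `Cc1ccc(NC2=CC(=O)c3nc4n(c3C2=O)[C@H]2OC[C@@H](O)[C@H]2OC4)cc1C` gives 2080 nM in this assay. Compound 3 `COc1ccccc1NC1=CC(=O)c2c(nc3n2[C@H]2OC[C@@H](O)[C@H]2OC3)C1=O` gives 6580 nM, so of these two numbers compound 1 stands at the lower end. Compound 2 `O=C1C(NC2CC2)=CC(=O)c2c1nc1n2[C@H]2OC[C@@H](O)[C@H]2OC1` gives > 16000 nM, which is a limit of the assay rather than a number.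

Within the data shown here, only one measured step alters the group on the amine nitrogen: an at least 2.4-fold lower number from compound 2 to compound 3 (0.38 log units; beyond the scatter), a move from a small saturated carbon ring to an aromatic ring. Compound 4 `O=C1C=C(NC2CCCC2)C(=O)c2c1nc1n2[C@H]2OC[C@@H](O)[C@H]2OC1` makes the opposite kind of move on compound 1: cyclopentyl in place of 3,4-dimethylphenyl on an amine nitrogen. Because an at least 2.4-fold lower number from compound 2 to compound 3 (0.38 log units; beyond the scatter) favoured the aromatic ring, the change to a saturated ring is expected to push the number upward, toward weaker inhibition. The new value may well come to rest at the limit of > 16000 nM in this assay, at which 1 of the 3 values shown sits. Compound 4 is therefore expected to give about 15000 nM, within a range of 5000 nM to 45000 nM. This estimate amounts to a 7.2-fold higher number from compound 1 to compound 4 (0.86 log units; beyond the scatter).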

Compound 4, half-maximal inhibitory concentration: > 16000 nM
Compound 4: a limit, no number (the forecaster's own chance of this, stated with the estimate: 50%); middle value at least 1.0-fold (0.02 log units) from the limit.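

Swapping 3,4-dimethylphenyl for cyclopentyl on this amine nitrogen gives an at least 7.6-fold higher number from compound 1 to compound 4 (0.88 log units; beyond the scatter) in this assay, and the full size of the step stays unknown, since the value of compound 4 is a limit. Set beside an at least 2.4-fold lower number from compound 2 to compound 3 (0.38 log units; beyond the scatter), this gives a second pair in which the compound with the aromatic ring has the lower number, now on the core of compound 1. Neither saturated ring, cyclopropyl in compound 2 or cyclopentyl in compound 4, yields a number in this assay, so the two cannot be ranked: the limit of > 16000 nM in this assay, at which 2 of the 4 values shown sit.

Still open, on these data alone, is whether the methyl groups of compound 1 contribute, which a plain phenyl group could test. Also open, as far as these compounds go, is whether an open chain such as n-butyl, or a saturated ring holding an amine such as piperidine, would return a measurable number.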